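From 2,3-dichlorophenyl to 3,4-dichlorophenyl on compound 3

The source may hold more compounds than are shown below. What is called first, only, known or untested is meant among the compounds shown, and "the series" means these compounds.

Of the compounds shown here, three have been measured in a functional assay on A549 cells (Homo sapiens) for antiproliferative activity, read by MTT assay, with a stated time of 72 h; on this read-out higher numbers stand for weaker inhibition and lower numbers for stronger inhibition. In it compound 1 (`NC1=NC2(CCSCC2)N(OCCCOc2ccc(Cl)c(Cl)c2)C(N)=N1`) gives 1 nM and compound 2 (`CC(C)(C)c1ccc(OCCCON2C(N)=NC(N)=NC23CCSCC3)cc1`) gives 1 nM, so these two stand level. Compound 3 (`NC1=NC2(CCOCC2)N(OCCCOc2cccc(Cl)c2Cl)C(N)=N1`) gives 100 nM, the highest number of the three, and its gap to each of the other two lies beyond the scatter of repeated measurements. On this read-out it is the weakest inhibitor of the set.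

Compound 4 (`NC1=NC2(CCOCC2)N(OCCCOc2ccc(Cl)c(Cl)c2)C(N)=N1`) has not yet been measured. It keeps the core of compound 3 and carries 3,4-dichlorophenyl in place of 2,3-dichlorophenyl on an oxygen on a saturated carbon.

For the measured compounds named here, no measured pair isolates this exchange, so its size in this assay can only be judged indirectly. Compound 1 carries the same 3,4-dichlorophenyl on a different core, and compound 1 gives 1 nM. A step beyond the scatter towards stronger inhibition is therefore expected, although the core of compound 3 is retained and the full gap may not be closed. The expected change is a 17-fold lower number from compound 3 to compound 4 (1.22 log units; beyond the scatter). For compound 4 the estimated value is 6 nM, with an expected range from 1 nM to 40 nM.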

Compound 4, half-maximal inhibitory concentration: 790 nM
The estimate for compound 4 lay 130-fold (2.12 log units) below the measured number; the whole stated range lies below it.
By their numbers in this assay, from the lowest: compounds 1 and 2 (each within the scatter of the next); then compound 3; then compound 4.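

With the core held fixed, exchanging 2,3-dichlorophenyl for 3,4-dichlorophenyl on an oxygen on a saturated carbon gives in this assay a 7.9-fold higher number from compound 3 to compound 4 (0.90 log units; beyond the scatter) and so moves towards weaker inhibition, which shows that this place responds to how the two chlorines are arranged, even though the leaving and entering groups have the same atoms. The 3,4-dichlorophenyl group therefore does not bring a low number with it wherever it stands: compound 1 gives 1 nM with this group on its own core, whereas compound 4 gives 790 nM with it on the core it shares with compound 3. Nothing among the data shown accounts for this step.

The compounds shown leave open whether 2,3-dichlorophenyl on the core of compound 1 would also give a lower number than 3,4-dichlorophenyl does there, which would tell whether the order of these two groups depends on the core. They also leave open how a phenyl ring carrying a single chlorine, or a methoxy group, would stand at this place on the core of compound 3.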